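Swapping the aryl hydrazone cap for a pyridyl

The compounds below may be only part of what the source reports. "The series", "measured", "known", "first", "only" and "open" are said of these compounds alone.

Measured compounds:
compound 1 `COc1cc2c(Oc3ccc(NC(=O)N/N=C/c4ccc(C(F)(F)F)cc4)cc3F)ccnc2cc1OCCCN1CCCC1`: 1300 nM
compound 2 `COc1cc2c(Oc3ccc(NC(=O)N/N=C/c4ccc(OC(F)(F)F)cc4)cc3F)ccnc2cc1OCCCN1CCCCC1`: 630 nM

In a functional assay on MKN-45 cells (Homo sapiens) for cytotoxicity, read by MTT assay, with a stated time of 72 h (a lower number here means a stronger inhibitor, a higher number a weaker inhibitor), compound 2 gives 630 nM, the lower of the two numbers recorded. Compound 1 gives 1300 nM in this assay, a gap beyond the scatter, so compound 2 is the stronger of the measured pair. Going by the values given here, the two differ in more than one place, so no single step between them is set out.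

Compound 3 `COc1cc2c(Oc3ccc(NC(=O)N/N=C/c4ccncc4)cc3F)ccnc2cc1OCCCN1CCCCC1` has not yet been measured in this assay. It keeps the shared core of compound 2 and differs only in one place: pyridin-4-yl in place of 4-(trifluoromethoxy)phenyl on a carbon with a double bond to nitrogen.

Among the compounds with values here, no measured pair separates this change alone. A smaller, heteroaromatic cap in place of the fluorinated aryl leaves the outcome open, but the account here leans to a loss. Compound 3 is expected to give roughly 1500 nM in this assay, within a range of 500 nM to 5000 nM. That estimate means a step of a 2.4-fold higher number from compound 2 to compound 3 (0.38 log units; beyond the scatter), expected to exceed the scatter, though its direction is uncertain.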

Compound 3, half-maximal inhibitory concentration: 980 nM
Estimate against measurement, compound 3: 1.5-fold (0.18 log units) above; the range from low to high includes it.
By their numbers in this assay, from the lowest: compounds 2, 3 and 1 (each within the scatter of the next, the first and the last beyond it).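

Going by these compounds alone, on the carbon with a double bond to nitrogen, pyridin-4-yl in place of 4-(trifluoromethoxy)phenyl gives a 1.6-fold higher number from compound 2 to compound 3 (0.19 log units; within the scatter) in this assay and is the only change here read in a single place. The two caps therefore cannot be told apart in this assay, which shows that a fluorinated cap is not needed at this position to stay within the scatter of compound 2. Nothing given here bears on why the two compounds read alike.

Going by these compounds, it remains open whether a cap bearing an amine or a carboxylic acid on this carbon would also stay within the scatter of compound 2. On these data alone, it is also open whether pyridin-4-yl would behave in the same way on the side chain that compound 1 carries.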